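Sulfamate series: replacing the amino substituent

The source may hold more compounds than are shown below. What is called first, only, known or untested is meant among the compounds shown, and "the series" means these compounds.

Compound 1 `CN(C)CCN(CCN(C)C)c1ccc(C(=O)N2CCc3ccc(OS(N)(=O)=O)cc3C2)cc1` stands at 3.8% in an assay on HEK293 cells for inhibition of Steryl-sulfatase (Homo sapiens), tested at 0.1 uM (a higher number here means a stronger effect of the compound at the concentration tested, a lower number a weaker effect), the lower of the two numbers in hand. Compound 2 `NS(=O)(=O)Oc1ccc2c(c1)CN(C(=O)c1cccc(N(Cc3ccccc3)Cc3ccco3)c1)CC2` gives 27.5% in this assay, and this gap lies beyond the scatter. Compound 3 `NS(=O)(=O)Oc1ccc2c(c1)CN(C(=O)c1ccc(N3CCCCC3)cc1)CC2` is not yet measured; it differs from compound 1 by piperidin-1-yl in place of bis(2-(dimethylamino)ethyl)amino on an aromatic carbon. Going by the values given here, no measured pair isolates this change, so its size is open; a small rise in this assay is expected, near the edge of the scatter, amounting to a number 8.2 percentage points higher from compound 1 to compound 3 (within the scatter). For compound 3 the estimated read-out in this assay is 12%, expected to fall between 0% and 30%.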

Compound 3, a percentage reported as inhibition, at one concentration (the size of the read-out at that concentration, not a potency): 11.5%
Compound 3: middle estimate off by 0.5 percentage points, on the high side; the measured number falls inside the stated range.
By their numbers in this assay, from the lowest: compounds 1 and 3 (each within the scatter of the next); then compound 2.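

In this assay, piperidin-1-yl in place of bis(2-(dimethylamino)ethyl)amino on an aromatic carbon para to a large group gives a number 7.7 percentage points higher from compound 1 to compound 3 (within the scatter) and so no separable change. At this position, a six-membered non-aromatic ring with fewer heavy atoms and a chain-bearing amino group without a ring therefore read alike. Nothing measured bears on the cause of this step.

On these data alone, whether morpholin-4-yl or a plain dimethylamino group on this carbon would move the read-out beyond the scatter remains open. So does the effect of a carboxylic acid there.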